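Swapping the pentylphenyl arm on a hydroxy-methoxyphenyl chalcone triazole

The source may hold more compounds than are shown below. What is called first, only, known or untested is meant among the compounds shown, and "the series" means these compounds.

Compound 1 `CCCCCc1ccc(-c2cn(-c3cccc(C(=O)/C=C/c4ccc(O)c(OC)c4)c3)nn2)cc1`: 5780 nM
Compound 2 `COc1cc(/C=C/C(=O)c2cccc(-n3cc(-c4ccccc4C(F)(F)F)nn3)c2)ccc1O`: 5070 nM
Compound 3 `CCCCCc1ccc(-c2cn(-c3cccc(C(=O)/C=C/c4ccc(OC)c(O)c4)c3)nn2)cc1`: > 30000 nM, which is a limit of the assay and not a number.

These three were run in a functional assay on RAW264.7 cells (Mus musculus) for inhibition, with a stated time of 4 days; a lower number here means a stronger inhibitor, a higher number a weaker inhibitor. Compound 4 `COc1ccc(/C=C/C(=O)c2cccc(-n3cc(-c4ccccc4C(F)(F)F)nn3)c2)cc1O` has not yet been measured. It differs from compound 3 by 2-(trifluoromethyl)phenyl in place of 4-pentylphenyl on an aromatic carbon. The same change, (2-(trifluoromethyl)phenyl in place of 4-pentylphenyl on an aromatic carbon), separates compound 1 from compound 2 and gave a 1.1-fold lower number from compound 1 to compound 2 (0.06 log units; within the scatter). The core of compound 3 differs from the core of compound 1 by 3-hydroxy-4-methoxyphenyl in place of 4-hydroxy-3-methoxyphenyl on a double-bonded chain carbon bound to a double-bonded chain carbon, which gave an at least 5.1-fold higher number from compound 1 to compound 3 (0.71 log units; beyond the scatter); compound 3 itself sits at the limit of > 30000 nM in this assay, at which 1 of the 3 values shown sits. The step from compound 3 to compound 4 is expected to be small, resting on the step of a 1.1-fold lower number from compound 1 to compound 2 (0.06 log units; within the scatter). The estimate implies a step that the limit leaves unreadable from compound 3 to compound 4, expected within the scatter. Compound 4 is therefore estimated at 40000 nM, between 15000 nM and 120000 nM, likely reported only as a limit.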

Compound 4, half-maximal inhibitory concentration: 9120 nM
Compound 4: middle estimate off by 4.4-fold (0.64 log units), on the high side; the measured number lies below the stated range.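

Exchanging 4-pentylphenyl for 2-(trifluoromethyl)phenyl in this assay gave an at least 3.2-fold lower number from compound 3 to compound 4 (0.51 log units; beyond the scatter) and did not repeat the step seen on the other core: the same change on two cores in this assay, a 1.1-fold lower number (0.06 log units; within the scatter) from compound 1 to compound 2 and an at least 3.2-fold lower number (0.51 log units; beyond the scatter) from compound 3 to compound 4, at least 2.8-fold (0.46 log units) apart, beyond the scatter of two such steps. The change from 4-hydroxy-3-methoxyphenyl to 3-hydroxy-4-methoxyphenyl gave a 1.8-fold higher number from compound 2 to compound 4 (0.25 log units; within the scatter) and likewise differed between the two cores: the same change on two cores in this assay, an at least 5.1-fold higher number (0.71 log units; beyond the scatter) from compound 1 to compound 3 and a 1.8-fold higher number (0.25 log units; within the scatter) from compound 2 to compound 4, at least 2.8-fold (0.46 log units) apart, beyond the scatter of two such steps. Compound 3 gives > 30000 nM which is a limit of the assay and not a number, leaving the true size of both gaps unread, and two pairs of cores do not show how either change would behave on a further core.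

The compounds shown leave open how an amine or a carboxylic acid on the arm would compare with 4-pentylphenyl and 2-(trifluoromethyl)phenyl. They also leave open whether a shorter alkyl chain would follow compound 1 or compound 3 in its response to these changes.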